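Replacing benzyl(methyl)amino with (2-hydroxyethyl)sulfanyl: expected cytotoxicity

This account rests on a few compounds, and the source may have more. Where it says the series, first, only, none or still open, it means among the compounds named here.

Values in a functional assay on Huh-7 cells (Homo sapiens) for cytotoxicity, read by MTT assay, with a stated time of 3 days (a higher number here means that more compound is tolerated, a lower number that less compound is tolerated), for the measured compounds:
- Compound 1 `[N-]=[N+]=NCc1ncnc2c1ncn2[C@@H]1O[C@H](CO)[C@@H](O)[C@H]1O` gives > 250000 nM as a limit
- Compound 2 `CN(Cc1ncnc2c1ncn2[C@@H]1O[C@H](CO)[C@@H](O)[C@H]1O)c1ccccc1` gives 21000 nM
- Compound 3 `CN(Cc1ccccc1)Cc1ncnc2c1ncn2[C@@H]1O[C@H](CO)[C@@H](O)[C@H]1O` gives 9000 nM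

Compound 3 holds the lowest number measured. The nearest step is modest (a 2.3-fold lower number from compound 2 to compound 3 (0.37 log units; beyond the scatter)). Compound 4 `OCCSCc1ncnc2c1ncn2[C@@H]1O[C@H](CO)[C@@H](O)[C@H]1O` carries (2-hydroxyethyl)sulfanyl in place of benzyl(methyl)amino on a saturated chain carbon bound to an aromatic carbon. The one six-membered aromatic ring of carbon only leaves with that group. The steps bearing on this are the two large ones from the ringless azido group (an at least 11-fold lower number from compound 1 to compound 2 (1.07 log units; beyond the scatter)) and (an at least 27-fold lower number from compound 1 to compound 3 (1.44 log units; beyond the scatter)). Read in reverse, they point to a large expected step to a higher number in this assay (an 11-fold higher number from compound 3 to compound 4 (1.05 log units; beyond the scatter)). Compound 4 is estimated at 100000 nM (expected range 30000 nM to 250000 nM).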

Compound 4, half-maximal cytotoxic concentration: > 100000 nM
Compound 4: no number, only a limit (the forecaster's own chance of this, stated with the estimate: 30%); the middle value sits exactly at the limit.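

Going by these compounds alone, at this saturated chain carbon, the two groups that brought a six-membered aromatic ring of carbon gave the only measured numbers in this assay. A ringless group other than azido, (2-hydroxyethyl)sulfanyl, now also gives a higher number than benzyl(methyl)amino (an at least 11-fold higher number from compound 3 to compound 4 (1.04 log units; beyond the scatter)) and methyl(phenyl)amino (an at least 4.7-fold higher number from compound 2 to compound 4 (0.67 log units; beyond the scatter)). For compound 4 the reading (> 100000 nM) is a limit, and the step involving compound 1 cannot be read.

The compounds shown do not separate the ring from the amine nitrogen, since all ringed groups here are amines. A benzylsulfanyl group or a simple dialkylamine at this carbon would tell these apart.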